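A few compounds are considered here, and "the series" means these few. Any claim that something is new, unique, unknown or untested is made for them only; others in the source may bear on it.

Compound 1 `COc1cc(-c2cc(/C=C/C(=O)c3ccc(N)cc3)[nH]n2)cc(OC)c1OC` has, in a functional assay on CAKI-1 cells (Homo sapiens) for inhibition, read by sulforhodamine B assay, with a stated time of 48 h (on this read-out higher numbers stand for weaker inhibition of growth and lower numbers for stronger inhibition of growth), only the entry "not determined" (no result reported) and so no number. Compound 2 `COc1ccc(C(=O)/C=C/c2cc(-c3cc(OC)c(OC)c(OC)c3)n[nH]2)cc1OC` gives 2200 nM in this assay, and compound 3 `COc1ccc(C(=O)/C=C/c2cc(-c3cc(OC)c(OC)c(OC)c3)n[nH]2)cc1` gives 2340 nM; the two stand within the scatter of each other, as the step of a 1.1-fold higher number from compound 2 to compound 3 (0.03 log units; within the scatter) shows, and no other number sits beside them. Compound 4 `COc1cc(-c2cc(/C=C/C(=O)c3ccc(F)c(F)c3)[nH]n2)cc(OC)c1OC` differs from compound 3 by 3,4-difluorophenyl in place of 4-methoxyphenyl on a carbonyl carbon. Among the compounds with values here, the only measured step that touches the 4-methoxyphenyl group is the one from compound 2 to compound 3, and it was small; no measured step puts fluorine on that group at all, so the bearing is slight. The expected step of a 1.3-fold higher number from compound 3 to compound 4 (0.11 log units; within the scatter) is therefore small, in no firm direction. Compound 4 is estimated at 3000 nM, with a range from 800 nM to 12000 nM.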

Compound 4, concentration for 50% growth inhibition: 2980 nM
For compound 4 the middle estimate is 1.0-fold (0.00 log units) above the measured one; measured number inside the range.
By their numbers in this assay, from the lowest: compounds 2, 3 and 4 (each within the scatter of the next).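

On the carbonyl carbon, 3,4-difluorophenyl can stand in place of either methoxy-bearing phenyl group without a step beyond the scatter in this assay, with a 1.3-fold higher number from compound 3 to compound 4 (0.11 log units; within the scatter) and a 1.4-fold higher number from compound 2 to compound 4 (0.13 log units; within the scatter) as the two steps. Earlier, this position had shown only the exchange of one methoxy for hydrogen; now all methoxy groups on that phenyl group are gone and fluorine has entered, and the numbers still lie within the scatter. Nothing available explains this agreement. Open, on these data alone, is whether a carboxylic acid on this phenyl group, or a longer chain in its place, would give a step beyond the scatter.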